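Benzyl(methyl)amino in Place of Piperidin-1-yl on the Sulfonyl

A few compounds are considered here, and "the series" means these few. Any claim that something is new, unique, unknown or untested is made for them only; others in the source may bear on it.

Measured compounds:
- compound 1 `CCOC(=O)[C@@H]1CCCN(S(=O)(=O)c2ccc(S(=O)(=O)N3CCCCC3)cc2)C1` gives 2900 nM in a functional assay on MIA PaCa-2 cells (Homo sapiens) for inhibition, read by MTT assay, with a stated time of 7 days; on this read-out lower numbers stand for stronger inhibition and higher numbers for weaker inhibition
- compound 2 `CCN(CC)S(=O)(=O)c1ccc(S(=O)(=O)N2CCC[C@@H](C(=O)NC3CN(C(=O)NC(C)(C)C)C3)C2)cc1` gives 3400 nM in this assay
- compound 3 `CCOC(=O)[C@@H]1CCCN(S(=O)(=O)c2ccc(S(=N)(=O)N(CC)CC)cc2)C1` gives 2600 nM in this assay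

On these three numbers compound 1 stands second highest, with compound 3 nearest and compound 2 furthest, both within the scatter of it. Compound 4 `CCOC(=O)[C@@H]1CCCN(S(=O)(=O)c2ccc(S(=O)(=O)N(C)Cc3ccccc3)cc2)C1` is not yet measured. It differs from compound 1 in one place: benzyl(methyl)amino in place of piperidin-1-yl on a sulfonyl sulfur.

For the measured compounds named here, the only measured step that touches this same position is the one from compound 1 to compound 3, where the whole piperidin-1-yl sulfonyl group was exchanged and the number barely moved: a 1.1-fold lower number from compound 1 to compound 3 (0.05 log units; within the scatter). Compound 2, which carries a diethylamino group on the sulfonyl at that position, also lies within the scatter of compound 1. Changing the amine on this sulfonyl sulfur has therefore not produced a step beyond the scatter so far, and no step beyond it is expected here either. Compound 4 is expected to give about 2800 nM in this assay, between 1200 nM and 6500 nM, which is an expected step of a 1.0-fold lower number from compound 1 to compound 4 (0.02 log units; within the scatter).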

Compound 4, half-maximal inhibitory concentration: > 30000 nM
Compound 4: only a limit was reported; the forecaster's own chance of this, stated with the estimate: 5%; middle value at least 10-fold (1.02 log units) from the limit.
By their numbers in this assay, from the lowest: compounds 3, 1 and 2 (each within the scatter of the next). At a limit, above all of these: compound 4.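

The amine on this sulfonyl sulfur is not a free choice in this assay: benzyl(methyl)amino in place of piperidin-1-yl gives an at least 10-fold higher number from compound 1 to compound 4 (1.01 log units; beyond the scatter). What compound 4 has is a limit, not a number: the limit of > 30000 nM in this assay, at which 1 of the 4 values shown sits. The exchange in a 1.1-fold lower number from compound 1 to compound 3 (0.05 log units; within the scatter) had suggested that this position accepts change freely, but compound 4 shows that this does not hold for every group placed here.

The compounds shown leave open whether the loss goes with the aromatic ring of the benzyl group or with the open methyl-bearing amine, since both change together; a cyclohexyl(methyl)amino group on the same sulfur would keep that amine without the aromatic ring and so separate the two. They also do not tell how far beyond its limit the true value of compound 4 lies.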